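Dimethylamino on the core of compound 1

This account rests on a few compounds, and the source may have more. Where it says the series, first, only, none or still open, it means among the compounds named here.

Measured in a physicochemical assay for metabolic stability, at pH 9.2; on this read-out higher numbers stand for a longer-lived compound and lower numbers for a shorter-lived compound:
- compound 1 `CCc1cccc2nc(-c3cccnc3N3CCN(C)CC3)oc(=O)c12` gives 1.08 h
- compound 2 `CCc1cccc2nc(-c3cccnc3N3CCC(C(=O)O)CC3)oc(=O)c12` gives 1.48 h

Going by the values given here, the only measured step is a 1.4-fold higher number from compound 1 to compound 2 (0.14 log units; within the scatter) and so compound 1 stands level with compound 2 on the numbers so far. Compound 3 `CCc1cc(N(C)C)cc2nc(-c3cccnc3N3CCN(C)CC3)oc(=O)c12` differs from compound 1 by dimethylamino in place of hydrogen on an aromatic carbon on the shared core. The measured step concerns the 4-methylpiperazin-1-yl group and not this aromatic carbon, so it sets no size here. A higher number in this assay is expected from the structural change alone, without measured support, and the estimated move is a 4.6-fold higher number from compound 1 to compound 3 (0.67 log units; beyond the scatter) for now. Compound 3 is estimated at 5 h with an expected range of 1.5 h to 20 h at this stage.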

Compound 3, half-life: 122 h
Estimate against measurement, compound 3: 24-fold (1.39 log units) below, outside the stated range (above it).
By their numbers in this assay, from the lowest: compounds 1 and 2 (each within the scatter of the next); then compound 3.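

Substitution on this aromatic carbon of the shared core, meta to an ethyl group, matters far more in this assay than the earlier change at the 4-methylpiperazin-1-yl group: dimethylamino in place of hydrogen gives a 110-fold higher number from compound 1 to compound 3 (2.05 log units; beyond the scatter) and stands well clear of compound 2. A single uncharged group here is therefore enough to carry the half-life beyond the scatter. Nothing measured explains the size of this step.

From the compounds shown here alone, it remains open whether amino or methoxy on this carbon would give a similar rise, and whether the rise holds with 4-carboxypiperidin-1-yl on the same core.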